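Swapping the Side Chain on the Nitrile Carbon

This account rests on a few compounds, and the source may have more. Where it says the series, first, only, none or still open, it means among the compounds named here.

Compound 1, `C#CCNC(=O)[C@H](CC(C)C)NC(=O)N1CCOCC1`, gives 97000 nM in an assay for inhibition of cathepsin S (Homo sapiens); a higher number here means a weaker inhibitor, a lower number a stronger inhibitor.
Compound 2, `CCCC[C@@H](C#N)NC(=O)[C@H](CC(C)C)NC(=O)N1CCOCC1`, gives 56 nM in this assay.
Compound 3, `CC(C)C[C@H](NC(=O)N1CCOCC1)C(=O)NC(C)(C)C#N`, gives 114 nM in this assay.

Compound 2 has the lowest number of the three. Compound 3 comes nearest, with a 2.0-fold higher number from compound 2 to compound 3 (0.31 log units; beyond the scatter), and compound 1 lies furthest, with a 1700-fold lower number from compound 1 to compound 2 (3.24 log units; beyond the scatter). Compound 4, `CC(C)C[C@H](NC(=O)N1CCOCC1)C(=O)N[C@H](C#N)COCc1ccccc1Cl`, differs from compound 2 in one place: (2-chlorobenzyl)oxy in place of propyl on a saturated chain carbon, two bonds along the chain from an amide-type nitrogen and a triple-bonded carbon. The large steps of a 1700-fold lower number from compound 1 to compound 2 (3.24 log units; beyond the scatter) and an 850-fold lower number from compound 1 to compound 3 (2.93 log units; beyond the scatter) both come from putting a nitrile-bearing group in place of propargyl, and compound 4 keeps that nitrile-bearing group, so those steps do not bear on this change. Only a 2.0-fold higher number from compound 2 to compound 3 (0.31 log units; beyond the scatter) alters what the saturated chain carbon carries, and that step was modest. For the measured compounds named here, no measured step introduces an aromatic ring or an ether oxygen here, so the direction is open. A modest step is therefore expected, and compound 4 is estimated at 35 nM, within 8 nM to 150 nM, which would mean an expected 1.6-fold lower number from compound 2 to compound 4 (0.20 log units; within the scatter).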

Compound 4, half-maximal inhibitory concentration: 9 nM
Beside the measured number, compound 4's estimate is 3.9-fold (0.59 log units) above it; measured number inside the range.
By their numbers in this assay, from the lowest: compound 4; then compound 2; then compound 3; then compound 1.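

Putting (2-chlorobenzyl)oxy in place of propyl on the saturated chain carbon gives a 6.2-fold lower number from compound 2 to compound 4 (0.79 log units; beyond the scatter) in this assay, so this position accepts far more than the small saturated groups seen so far. The earlier change here, a 2.0-fold higher number from compound 2 to compound 3 (0.31 log units; beyond the scatter), moved the number only upward, whereas this one shows that a group carrying an aromatic ring and an ether oxygen can take the number lower. Nothing measured here explains the drop.

This single step brings in the ring, the ether oxygen and the chlorine together, so their separate shares cannot be told apart. From the compounds shown here alone, whether a plain benzyloxy group without the chlorine would give the same drop remains open, as does how a carboxylic acid or an amine would fare on this carbon.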